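Swapping the aryl group on a coumarin-pyrimidine cytotoxicity series

A few compounds are considered here, and "the series" means these few. Any claim that something is new, unique, unknown or untested is made for them only; others in the source may bear on it.

Measured compounds:
compound 1, `N#Cc1c(-c2c(F)cccc2Cl)cc(-c2c(O)c3ccccc3oc2=O)nc1N`, 46300 nM
compound 2, `COc1cccc(-c2cc(-c3c(O)c4ccccc4oc3=O)nc(O)n2)c1`, 5550 nM

Of the compounds shown here, two have been tested in a functional assay on A549 cells (Homo sapiens) for cytotoxicity, read by MTT assay; on this read-out lower numbers stand for stronger inhibition and higher numbers for weaker inhibition. Compound 1 is built with a nitrile and an amino group on its central ring and gives 46300 nM. Compound 2 carries a hydroxy group on that ring instead and a 3-methoxyphenyl group, and in this assay compound 2 gives 5550 nM. Of the two numbers compound 2 is the lower, and its gap to compound 1 is beyond the usual scatter, so compound 2 is the stronger inhibitor of the pair.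

Compound 3, `O=c1oc2ccccc2c(O)c1-c1cc(-c2ccc(F)cc2)nc(O)n1`, has not yet been measured. It keeps the core of compound 2 and differs in one place: 4-fluorophenyl in place of 3-methoxyphenyl on an aromatic carbon. No pair of measured compounds differs by this single change, so nothing shown here tells how such a swap moves this read-out. The expectation is a step from compound 2 to compound 3 of a 1.1-fold higher number from compound 2 to compound 3 (0.03 log units; within the scatter), in either direction or none beyond the scatter. Compound 3 is therefore estimated at 6000 nM, within a range from 2000 nM to 18000 nM.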

Compound 3, half-maximal inhibitory concentration: 2390 nM
The estimate for compound 3 lay 2.5-fold (0.40 log units) above the measured number, and the stated range covers the measured number.
By their numbers in this assay, from the lowest: compound 3; then compound 2; then compound 1.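

In this assay, going by these compounds alone, the aryl group on this aromatic carbon, next to the ring nitrogen, can be read directly for the first time: putting 4-fluorophenyl in place of 3-methoxyphenyl gives a 2.3-fold lower number from compound 2 to compound 3 (0.37 log units; beyond the scatter), a modest step, but enough to show that the group at this position affects the read-out. The group that leaves carries a hydrogen-bond acceptor and the one that enters carries none, so for this pair an acceptor on the aryl group is not required for the lower number. Nothing available accounts for the step, which therefore stands as an observation and not as an explanation.

The swap changes both the substituent and where it sits on the phenyl group, so the compounds shown cannot separate these two changes from each other. From the compounds shown here alone, it also remains open how a plain phenyl group, or a phenyl group bearing an amine or a carboxylic acid, would read at this position on the same core.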